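Swapping 3-bromo-4-fluorophenyl for 1,3-thiazol-2-yl on the amide

The source may report more compounds than this note shows. Statements on the series, on what has been measured and on what is new or still open speak of the compounds shown alone.

Of the compounds shown here, three sharing one core have been tested so far, and they differ only in the group on the amide-type nitrogen. Going by the values given here, in a functional assay on MCF7 cells (Homo sapiens) for inhibition, read by MTT assay, with a stated time of 72 h (a higher number here means a weaker inhibitor, a lower number a stronger inhibitor), compound 3 `O=C(Nc1ccc(F)c(Br)c1)C1CCN(C/C=C/c2ccccc2)CC1` gives 13500 nM, the only true number among them. Compound 1 `COc1ccc(NC(=O)C2CCN(C/C=C/c3ccccc3)CC2)cc1` reads > 100000 nM, which is a limit of the assay and not a number. Compound 2 `COc1ccccc1NC(=O)C1CCN(C/C=C/c2ccccc2)CC1` reads > 100000 nM, which is also a limit.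

The next compound is compound 4 `O=C(Nc1nccs1)C1CCN(C/C=C/c2ccccc2)CC1`, not yet measured, with 1,3-thiazol-2-yl in place of 3-bromo-4-fluorophenyl on the amide-type nitrogen: 1,3-thiazol-2-yl in place of 3-bromo-4-fluorophenyl on an amide-type nitrogen.

The relevant evidence comes from earlier changes at this same place. Installing 3-bromo-4-fluorophenyl gave an at least 7.4-fold lower number from compound 1 to compound 3 (0.86 log units; beyond the scatter), and it also gave an at least 7.4-fold lower number from compound 2 to compound 3 (0.86 log units; beyond the scatter). Exchanging the two methoxyphenyl groups gave a step that the two limits leave unreadable from compound 1 to compound 2, so that pair offers no guide. None of these compounds carries a thiazole, which keeps any forecast loose.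

Both groups that replaced 3-bromo-4-fluorophenyl so far ended at the limit, so a move towards a weaker inhibitor seems the likelier outcome. The estimated change is a 3.3-fold higher number from compound 3 to compound 4 (0.52 log units; beyond the scatter), a modest step to a higher number. For compound 4 the expected value is 45000 nM, with an estimated range of 15000 nM to 100000 nM.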

Compound 4, half-maximal inhibitory concentration: 28600 nM
Compound 4: middle estimate off by 1.6-fold (0.20 log units), on the high side; measured number inside the range.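

Between two true numbers, this position now gives a 2.1-fold higher number from compound 3 to compound 4 (0.33 log units; beyond the scatter) in this assay, and compound 4 shows that neither bromine nor fluorine on a six-membered ring is required for a true reading. Compound 4 also separates from the two methoxyphenyl compounds, with an at least 3.4-fold lower number from compound 2 to compound 4 (0.54 log units; beyond the scatter) and with an at least 3.4-fold lower number from compound 1 to compound 4 (0.54 log units; beyond the scatter), so leaving 3-bromo-4-fluorophenyl does not by itself lead to the limit. Those two steps stay open at one end, as compound 1 and compound 2 each sit at a limit of the assay and not at a number: the limit of > 100000 nM in this assay, at which 2 of the 4 values shown sit.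

The four compounds leave open whether the difference between compound 3 and compound 4 follows the bromine, the fluorine or the ring itself, as no group shown carries only one of these features. Also open, as far as these compounds go, is how a plain phenyl, a 4-chlorophenyl or a pyridin-2-yl on the amide-type nitrogen would read in this assay, and so whether 1,3-thiazol-2-yl and 3-bromo-4-fluorophenyl belong to one trend at this position or are two separate cases.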